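The compounds below may be only part of what the source reports. "The series", "measured", "known", "first", "only" and "open" are said of these compounds alone.

Of the compounds shown here, three that share one core have been measured in an assay on CHO cells for agonist activity at Neuronal acetylcholine receptor; alpha3/alpha6/beta2/beta3 (Homo sapiens), read by FLIPR and calcium flux; on this read-out higher numbers stand for an effect only at larger amounts of compound and lower numbers for an effect already at smaller amounts. Compound 1 `CCCC(=O)N1CC2CC(C1)N2` carries a propyl chain on the carbonyl carbon, and in this assay compound 1 gives 300 nM. This is the lowest number of the three. Compound 2 `O=C(C1CCCC1)N1CC2CC(C1)N2`, with a cyclopentyl ring on the carbonyl carbon, gives 1600 nM, a value clearly higher than that of compound 1. Compound 3 `O=C(CC1C=CCC1)N1CC2CC(C1)N2` gives 21000 nM, the highest number of the set; the step from compound 1 to compound 3 is a 70-fold higher number from compound 1 to compound 3 (1.85 log units; beyond the scatter).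

Compound 4 `O=C([C@@H]1C[C@@H]1F)N1CC2CC(C1)N2` has not yet been measured. It differs from compound 1 in one place: 2-fluorocyclopropyl in place of propyl on a carbonyl carbon. Both measured steps bear on this change, since each also replaces part or all of the propyl chain of compound 1 with a ring, and both led to higher numbers in this assay. Compound 4 sets a ring directly on the carbonyl carbon, and so the closest comparison is compound 2, which also does this and which gives 1600 nM. The ring in compound 4 is smaller than that of compound 2, so a more moderate rise is expected.

The expected step is therefore a 2.7-fold higher number from compound 1 to compound 4 (0.43 log units; beyond the scatter), and compound 4 is estimated to give 800 nM in this assay, with a range from 250 nM to 2500 nM.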

Compound 4, half-maximal effective concentration: 88 nM
Compound 4: the middle estimate sits 9.1-fold (0.96 log units) above what was measured; measured number below the stated range.
By their numbers in this assay, from the lowest: compound 4; then compound 1; then compound 2; then compound 3.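

Replacing propyl with 2-fluorocyclopropyl on the carbonyl carbon gives a 3.4-fold lower number from compound 1 to compound 4 (0.53 log units; beyond the scatter) in this assay, the only ring-bearing change shown here that moves the number downward. Compound 2 and compound 3 also carry rings and both stand above compound 1, so a ring in this part of the molecule does not always raise the number, and what matters is which ring is present: compound 2, with cyclopentyl on the same carbonyl carbon, gives 1600 nM, while compound 4 gives 88 nM in the same test. No measurement shown here accounts for why this change lowers the number.

The compounds shown leave open whether the lower number goes with the three-membered ring, the fluorine or the two defined stereocentres, as all three enter together in a single change. A plain cyclopropyl group on the carbonyl carbon, or a 2-fluorocyclopropyl group with the opposite arrangement at its stereocentres, would help separate these contributions, and a cyclobutyl ring would show how the number follows ring size.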